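Phenyl exchange on the chain: from compound 2 to compound 3

The source may hold more compounds than are shown below. What is called first, only, known or untested is meant among the compounds shown, and "the series" means these compounds.

- compound 1 `O=C(/C=C/c1ccc([N+](=O)[O-])cc1)Nc1cc2c(Nc3ccc(F)c(Cl)c3)ncnc2cc1O[C@H]1CCOC1` gives 26700 nM as measured
- compound 2 `O=C(/C=C/c1cccc(Cl)c1Cl)Nc1cc2c(Nc3ccc(F)c(Cl)c3)ncnc2cc1O[C@H]1CCOC1` gives 30100 nM as measured

Both numbers come from a functional assay on MCF7 cells (Homo sapiens) for cytotoxicity, read by MTT assay, with a stated time of 72 h (on this read-out lower numbers stand for stronger inhibition and higher numbers for weaker inhibition), and cannot be told apart. Going by the values given here, compound 2 therefore stands level with its only measured neighbour, and the series offers no order yet.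

Compound 3 `COc1ccc(/C=C/C(=O)Nc2cc3c(Nc4ccc(F)c(Cl)c4)ncnc3cc2O[C@H]2CCOC2)c(OC)c1` has not been measured. Its change is 2,4-dimethoxyphenyl in place of 2,3-dichlorophenyl on a double-bonded chain carbon bound to a double-bonded chain carbon and puts 2,4-dimethoxyphenyl in place of 2,3-dichlorophenyl on a double-bonded chain carbon bound to a double-bonded chain carbon.

Among the compounds with values here, one measured step bears on this. At the same place, 2,3-dichlorophenyl replaced 4-nitrophenyl, and that exchange gave a 1.1-fold higher number from compound 1 to compound 2 (0.05 log units; within the scatter) as its whole effect. On the strength of that single step, no shift beyond the scatter is expected in this assay for the new exchange. Within the data shown here, no measured compound carries 2,4-dimethoxyphenyl, so the range is kept wide in both directions.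

The estimated step is a 1.2-fold lower number from compound 2 to compound 3 (0.08 log units; within the scatter) on this reasoning.

For compound 3 the expected value is 25000 nM with an estimated range from 10000 nM to 55000 nM in this read-out.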

Compound 3, half-maximal inhibitory concentration: 28600 nM
Beside the measured number, compound 3's estimate is 1.1-fold (0.06 log units) below it; the measured number falls inside the stated range.
By their numbers in this assay, from the lowest: compounds 1, 3 and 2 (each within the scatter of the next).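

In this assay putting 2,4-dimethoxyphenyl in place of 2,3-dichlorophenyl on a double-bonded chain carbon bound to a double-bonded chain carbon gives a 1.1-fold lower number from compound 2 to compound 3 (0.02 log units; within the scatter) and putting it in place of 4-nitrophenyl at the same place gives a 1.1-fold higher number from compound 1 to compound 3 (0.03 log units; within the scatter) so compound 1, compound 2 and compound 3 remain level, with no order among them. The step from compound 2 to compound 3 differs from the earlier exchange in what it adds: the entering group has more heavy atoms than 2,3-dichlorophenyl and carries hydrogen-bond acceptors that 2,3-dichlorophenyl lacks, yet the number does not move beyond the scatter. No measurement at hand accounts for these three numbers lying together.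

Three substituted phenyl groups are too few to show whether this place is insensitive to exchange in general or whether these three groups merely happen to give level numbers. Still open, going by these compounds, is whether an amine such as dimethylamino or a carboxylic acid on the phenyl ring, or a longer chain in place of the ethenyl link, would shift the number beyond the scatter.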